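Pyridyl to Chlorophenyl on a Triazole-Bearing Core

The source may hold more compounds than are shown below. What is called first, only, known or untested is meant among the compounds shown, and "the series" means these compounds.

Going by the values given here, compound 2 `C=C1C(=O)[C@]23C[C@@]1(O)CC[C@H]2c1ccc(OS(=O)(=O)c2ccc(C)cc2)c(C)c1[C@@H]3Cn1cc(-c2ccccn2)nn1` is the one compound here with an actual number in a functional assay on SW480 cells (Homo sapiens) for cytotoxicity, read by MTT assay, with a stated time of 4 days (a higher number here means a weaker inhibitor, a lower number a stronger inhibitor), giving 1970 nM. Compound 1 `C=C1C[C@]23C[C@@]1(O)CC[C@H]2c1ccc(O)c(C)c1[C@@H]3Cn1cc(-c2ccccn2)nn1` reaches only the limit of this assay, > 20000 nM. Compound 3 `C=C1C[C@]23C[C@@]1(O)CC[C@H]2c1ccc(OS(=O)(=O)c2ccc(C)cc2)c(C)c1[C@@H]3Cn1cc(-c2ccc(Br)cc2)nn1` likewise reaches only the limit, > 20000 nM. Two of the three values thus sit at the limit of > 20000 nM in this assay, at which 2 of the 3 values shown sit, leaving compound 2 standing alone with a measured value. Compound 4 `C=C1C(=O)[C@]23C[C@@]1(O)CC[C@H]2c1ccc(OS(=O)(=O)c2ccc(C)cc2)c(C)c1[C@@H]3Cn1cc(-c2ccc(Cl)cc2)nn1` carries the change (4-chlorophenyl in place of pyridin-2-yl on an aromatic carbon). Among the compounds with values here, no measured step between two compounds differing in one place exists, so the size of this step cannot be read from neighbours. A loss of potency beyond the scatter is expected for compound 4, since compound 3 without the pyridin-2-yl gave > 20000 nM, though compound 3 also differs in its core. Compound 4 is expected at 5000 nM, between 1500 nM and 20000 nM, a step of a 2.5-fold higher number from compound 2 to compound 4 (0.40 log units; beyond the scatter).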

Compound 4, half-maximal inhibitory concentration: 2390 nM
Compound 4: the middle estimate sits 2.1-fold (0.32 log units) above what was measured; the range from low to high includes it.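

At this aromatic carbon of the five-membered ring, 4-chlorophenyl in place of pyridin-2-yl gives a 1.2-fold higher number from compound 2 to compound 4 (0.08 log units; within the scatter) in this assay. On this core, then, the position takes a ring of carbon only, without the ring nitrogen and hydrogen-bond acceptor of pyridin-2-yl, and the two compounds cannot be told apart. Nothing shown here bears on why the swap leaves the reading within the scatter. As far as these compounds go, what an amine or a carboxylic acid at this carbon would do stays open, and so does the part played by the chlorine alone.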